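The source may hold more compounds than are shown below. What is called first, only, known or untested is meant among the compounds shown, and "the series" means these compounds.

Within the data shown here, in a physicochemical assay for metabolic stability, in the presence of a further agent that is not named here (a lower number here means that the compound disappears faster, a higher number that the compound lasts longer), none of the three compounds measured so far has given a number, only a limit. Compound 2 `Cc1cn([C@H]2C[C@H](SSc3ccc([N+](=O)[O-])cc3)[C@@H](CO)O2)c(=O)[nH]c1=O`, which carries 4-nitrophenyl on a sulfur, stands at < 0.167 h, and this is a limit. Compound 1 `Cc1cn([C@H]2C[C@H](SSC(Cl)(Cl)Cl)[C@@H](CO)O2)c(=O)[nH]c1=O`, with trichloromethyl on a sulfur, stands at < 1.5 h, also a limit. Compound 3 `CCCCCCSS[C@H]1C[C@H](n2cc(C)c(=O)[nH]c2=O)O[C@@H]1CO`, with hexyl on a sulfur, stands at < 8 h, again a limit.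

Compound 4 `Cc1cn([C@H]2C[C@H](SSCCO)[C@@H](CO)O2)c(=O)[nH]c1=O` differs from compound 2 in one place: 2-hydroxyethyl in place of 4-nitrophenyl on a sulfur. In words, 2-hydroxyethyl takes the place of 4-nitrophenyl on a sulfur. The nearest guide is a step that the two limits leave unreadable from compound 2 to compound 3, which also replaces 4-nitrophenyl with a chain, in that case hexyl. The other two measured steps, a step that the two limits leave unreadable from compound 1 to compound 2 and a step that the two limits leave unreadable from compound 1 to compound 3, give no size either. Among the measured compounds shown here, no measured step therefore fixes how large the change should be, and the expectation rests on the limits alone. These leave more room for a longer half-life with a chain on the sulfur than with 4-nitrophenyl, so a rise is expected, though with wide uncertainty. The expected change is an at least 8.9-fold higher number from compound 2 to compound 4 (0.95 log units; beyond the scatter), towards a longer half-life. For compound 4 the estimated half-life is 1.5 h, with an expected range from 0.2 h to 8 h.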

Compound 4, half-life: < 8 h
Compound 4: a limit, no number; the forecaster's own chance of this, stated with the estimate: 60%; the middle value is on the limit's open side.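

In this assay compound 4 stands at < 8 h, which is a limit and not a number. The steps to compound 4 from compound 1, compound 2 and compound 3 join limit to limit and cannot be read. The compounds shown leave open the actual half-life of all four, and so whether 2-hydroxyethyl on a sulfur lasts longer than 4-nitrophenyl, trichloromethyl or hexyl.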